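Hydrazone-thiazole series: second methoxy step, compound 4 pending

The source may report more compounds than this note shows. Statements on the series, on what has been measured and on what is new or still open speak of the compounds shown alone.

Measured so far:
compound 1 `COc1ccccc1-c1csc(N/N=C/c2ccc(F)c(F)c2)n1`: 61300 nM
compound 2 `Fc1ccc(/C=N/Nc2nc(-c3ccccc3)cs2)cc1F`: 91400 nM
compound 3 `COc1cc(/C=N/Nc2nc(-c3ccccc3)cs2)cc(Br)c1OC`: 40000 nM

All three numbers come from a functional assay on A549 cells (Homo sapiens) for inhibition, read by MTT assay, with a stated time of 48 h; on this read-out lower numbers stand for stronger inhibition and higher numbers for weaker inhibition. Compound 1 differs from compound 2 by methoxy in place of hydrogen on an aromatic carbon, and that change gave a 1.5-fold lower number from compound 2 to compound 1 (0.17 log units; within the scatter), a step within the scatter, so nothing can be read from it. The difference between the core of compound 2 and the core of compound 3 is not broken down here; their values show compound 3 and compound 2 beyond the scatter of each other, while compound 3 and compound 1 lie within it.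

Compound 4 `COc1ccccc1-c1csc(N/N=C/c2cc(Br)c(OC)c(OC)c2)n1` is not yet measured. It differs from compound 3 by methoxy in place of hydrogen on an aromatic carbon, the same kind of change as from compound 2 to compound 1, at the same kind of place. For the measured compounds named here, the expectation in this assay is a step of a 1.3-fold lower number from compound 3 to compound 4 (0.12 log units; within the scatter), again within the scatter, resting on the one earlier instance, because a 1.5-fold lower number from compound 2 to compound 1 (0.17 log units; within the scatter) was small. For compound 4 the estimated value is 30000 nM, with a range from 12000 nM to 80000 nM expected.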

Compound 4, half-maximal inhibitory concentration: 94900 nM
Estimate against measurement, compound 4: 3.2-fold (0.50 log units) below; the whole stated range lies below it.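

In this assay, the methoxy change now gives a 2.4-fold higher number from compound 3 to compound 4 (0.38 log units; beyond the scatter). Set beside the earlier step, this shows that phenyl to 2-methoxyphenyl does not give a result that can be carried unchanged between these two cores: the same change on two cores in this assay, a 1.5-fold lower number (0.17 log units; within the scatter) from compound 2 to compound 1 and a 2.4-fold higher number (0.38 log units; beyond the scatter) from compound 3 to compound 4, 3.5-fold (0.55 log units) apart, beyond the scatter of two such steps. It does not give a rule for the series: there are only two instances, the earlier step lies within the scatter and so sets no direction of its own, and the data do not show which feature of the two cores accounts for the gap.

The compounds shown leave open whether the higher number on the core of compound 3 would recur on any further core, or whether it is specific to this one pairing. They also leave open whether it belongs to methoxy itself, a question that other groups at the same place, such as hydroxyl, an amine or a carboxylic acid, could address on both cores.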